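This account rests on a few compounds, and the source may have more. Where it says the series, first, only, none or still open, it means among the compounds named here.

Measured in a functional assay on LNCaP cells (Homo sapiens) for antiproliferative activity, read by WST assay, with a stated time of 3 days; a lower number here means a stronger inhibitor, a higher number a weaker inhibitor:
Compound 1 `CCCCCCCOc1c(-c2cc(OC)c(OC)c(OC)c2)oc2ccccc2c1=O`: > 50000 nM
Compound 2 `CCC(C)Oc1c(-c2cc(OC)c(OC)c(OC)c2)oc2ccccc2c1=O`: 9300 nM

The entry for compound 1 is a limit of the assay. Among the compounds with values here, compound 2, at 9300 nM, holds the only actual number in this assay. Compound 3 `CCCN(CCC)CCCCOc1c(-c2cc(OC)c(OC)c(OC)c2)oc2ccccc2c1=O` differs from it as follows: 4-(dipropylamino)butyl in place of sec-butyl on an oxygen on an aromatic ring. Within the data shown here, one measured step bears on this place: an at least 5.3-fold lower number from compound 1 to compound 2 (0.73 log units; beyond the scatter), which lies beyond the scatter. Neither compound in that step carries a nitrogen in its chain, and the step fixes no direction for the new group. The expected step is a 1.9-fold lower number from compound 2 to compound 3 (0.27 log units; within the scatter), which would not go beyond the scatter. For compound 3 the estimated value is 5000 nM, with an expected range of 1200 nM to 25000 nM.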

Compound 3, half-maximal inhibitory concentration: 16800 nM
For compound 3 the middle estimate is 3.4-fold (0.53 log units) below the measured one; the range from low to high includes it.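

In this assay, a chain carrying a nitrogen on this oxygen does not separate from the small sec-butyl group, with a 1.8-fold higher number from compound 2 to compound 3 (0.26 log units; within the scatter). A large chain at this place therefore need not end at the limit seen with heptyl, since dipropylamino in place of propyl gives an at least 2.9-fold lower number from compound 1 to compound 3 (0.47 log units; beyond the scatter). That step is only a bound, because compound 1 stands at a limit of the assay: the limit of > 50000 nM in this assay, at which 1 of the 3 values shown sits.

The compounds shown leave open whether a shorter chain ending in the same amine, a piperidine or a carboxylic acid at the chain end would move the number beyond the scatter.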